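Shortening the Amine Chain of Compound 2

A few compounds are considered here, and "the series" means these few. Any claim that something is new, unique, unknown or untested is made for them only; others in the source may bear on it.

- compound 1 `CC(C)Nc1c(O)cc2oc(-c3ccccc3)cc(=O)c2c1O` in an ADME assay on Hippocampus (Mus musculus), read by LDH release (a lower number here means that less compound is tolerated, a higher number that more compound is tolerated), gives 152 uM
- compound 2 `CC(C)CCNc1c(O)cc(O)c2c(=O)cc(-c3ccccc3)oc12` in this assay gives 16 uM

Of the two measured compounds, compound 2 has the lower number (16 uM), and so the less compound is tolerated. Compound 1 (152 uM) stands higher, and the gap between the two lies beyond the scatter.

The next compound is compound 3 `CCCNc1c(O)cc(O)c2c(=O)cc(-c3ccccc3)oc12`, which is still unmeasured. It differs from compound 2 by methyl in place of isopropyl on a saturated chain carbon, two bonds along the chain from a nitrogen on an aromatic ring and thus has methyl in place of isopropyl on a saturated chain carbon, two bonds along the chain from a nitrogen on an aromatic ring. Cut one bond further out, the same difference reads isopentylamino to propylamino.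

Going by the values given here, no measured step shows this change, so the expectation rests on little. Among the compounds with values here, the only higher reference is compound 1 (152 uM), and a move in that direction seems more likely than a fall. A modest rise in this assay is expected, slightly beyond the scatter, and the estimated step is a 2.8-fold higher number from compound 2 to compound 3 (0.45 log units; beyond the scatter) in size. For compound 3 the estimate is 45 uM (expected range 18 uM to 120 uM) in this assay when it is measured.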

Compound 3, half-maximal toxic concentration: 28 uM
Compound 3: middle estimate off by 1.6-fold (0.21 log units), on the high side, and the stated range covers the measured number.
By their numbers in this assay, from the lowest: compounds 2 and 3 (each within the scatter of the next); then compound 1.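

In this assay, methyl in place of isopropyl on a saturated chain carbon, two bonds along the chain from a nitrogen on an aromatic ring, gives a 1.8-fold higher number from compound 2 to compound 3 (0.24 log units; within the scatter) and stays within the scatter, so the isopentylamino and propylamino compounds cannot be told apart here. Going by these compounds alone, this is the first step that changes the amine chain alone on an otherwise unchanged structure, and it shows that this shortening, taken by itself, does not produce a difference that can be read in this assay. Nothing at hand bears on why the two chains read alike.

Compound 1, at 152 uM, differs from compound 2 and compound 3 in more than one place, so the shown compounds do not tie its higher number to the chain or to any other single feature. As far as these compounds go, whether this flat reading holds beyond these two chains remains open, for a shorter ethylamino or plain amino group, for a longer chain such as octylamino, and for a chain carrying a hydroxyl group or a carboxylic acid.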